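From compound 3 to compound 4: a ring swap

The compounds below may be only part of what the source reports. "The series", "measured", "known", "first", "only" and "open" are said of these compounds alone.

Values in an ADME assay on microsomes from liver (Homo sapiens) for pharmacokinetics, read by LC-MS, using NADPH, with a stated time of 45 min, tested at 1 uM; on this read-out lower numbers stand for slow clearance and higher numbers for fast clearance:
- Compound 1 `Nc1nccc(COc2cc(F)c3nc(N[C@@H]4CCCC[C@H]4O)sc3c2)c1Cl`: 19 mL/min/kg
- Compound 2 `COc1cc(OCc2ccnc(Nc3ccn(C)n3)n2)cc2sc(N[C@H]3CCCC[C@@H]3O)nc12`: 17 mL/min/kg
- Compound 3 `COc1cc(OCc2ccnc(Nc3cn[nH]c3)n2)cc2sc(N[C@H]3CCCC[C@@H]3O)nc12`: 32 mL/min/kg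

At 32 mL/min/kg, compound 3 lies within the usual scatter of both other compounds, so these numbers do not separate it from them. Compound 4 `COc1cc(OCc2ccnc(Nc3cn(C)nn3)n2)cc2sc(N[C@H]3CCCC[C@@H]3O)nc12` differs from it as follows: 1-methyl-1H-1,2,3-triazol-4-yl in place of 1H-pyrazol-4-yl on a nitrogen on an aromatic ring. In words, 1-methyl-1H-1,2,3-triazol-4-yl stands in place of 1H-pyrazol-4-yl on a nitrogen on an aromatic ring. For the measured compounds named here, one measured step bears on this, a swap of ring at the same kind of place: a 1.9-fold higher number from compound 2 to compound 3 (0.27 log units; within the scatter). It stays within the scatter, so no real shift is expected here. The expected change is a 1.5-fold lower number from compound 3 to compound 4 (0.16 log units; within the scatter), a slightly lower number that would also stay within the scatter. The estimate for compound 4 is 22 mL/min/kg, with an expected range from 11 mL/min/kg to 42 mL/min/kg.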

Compound 4, clearance: 43 mL/min/kg
For compound 4 the middle estimate is 2.0-fold (0.29 log units) below the measured one; the whole stated range lies below it.
By their numbers in this assay, from the lowest: compounds 2, 1, 3 and 4 (each within the scatter of the next, the first and the last beyond it).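

With a 1.3-fold higher number from compound 3 to compound 4 (0.13 log units; within the scatter), the 1-methyl-1H-1,2,3-triazol-4-yl group cannot be told apart from the 1H-pyrazol-4-yl group in this assay. Set against the 1-methyl-1H-pyrazol-3-yl group, however, it gives a 2.5-fold higher number from compound 2 to compound 4 (0.40 log units; beyond the scatter), the first step at this place to pass the scatter, so the choice of ring on this nitrogen can shift the clearance modestly. No measurement at hand explains that step. Still open, as far as these compounds go, is how a triazole without the methyl group, or a phenyl ring or cyclopropyl group, would read at this place.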